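The source may report more compounds than this note shows. Statements on the series, on what has been measured and on what is new or still open speak of the compounds shown alone.

Going by the values given here, compound 2 `CCCCn1c(Cc2cc(OC)c(OC)c(OC)c2)nc2c(N)nc(F)nc21` gives 185000000 nM in a functional assay on MCF7 cells (Homo sapiens) for cytotoxicity (on this read-out higher numbers stand for an effect only at larger amounts of compound and lower numbers for an effect already at smaller amounts), the highest of the two numbers so far; compound 1 `COc1cc(Cc2nc3c(N)ncnc3n2CCCO)cc(OC)c1OC` gives 92700000 nM in this assay, and the two values lie within the scatter of each other, so no order between them is claimed. Compound 3 `C#CCCn1c(Cc2cc(OC)c(OC)c(OC)c2)nc2c(N)nc(F)nc21` differs from compound 2 by ethynyl in place of ethyl on a saturated chain carbon, two bonds along the chain from an aromatic nitrogen. Among the compounds with values here, no step between measured compounds bears on this change. The expected step from compound 2 to compound 3 in this assay, a 1.0-fold lower number from compound 2 to compound 3 (0.01 log units; within the scatter), is none beyond the scatter, since nothing measured points either way. Compound 3 is therefore estimated at 180000000 nM, within 50000000 nM to 600000000 nM.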

Compound 3, half-maximal effective concentration: 286000000 nM
Estimate against measurement, compound 3: 1.6-fold (0.20 log units) below; the measured number falls inside the stated range.
By their numbers in this assay, from the lowest: compounds 1, 2 and 3 (each within the scatter of the next, the first and the last beyond it).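

In this assay, ethynyl in place of ethyl on a saturated chain carbon, two bonds along the chain from an aromatic nitrogen, gives a 1.5-fold higher number from compound 2 to compound 3 (0.19 log units; within the scatter) and so stays inside the scatter. Going by these compounds alone, this is the first single-place reading on this chain, since compound 1 and compound 2 differ in more than one place. No measured evidence accounts for this result.

Going by these compounds, whether a longer chain, an amine or a carboxylic acid in place of the butyl would move the number beyond the scatter remains open. Also open, on these data alone, is whether the same change would read alike on the core of compound 1.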